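A few compounds are considered here, and "the series" means these few. Any claim that something is new, unique, unknown or untested is made for them only; others in the source may bear on it.

Values in a functional assay on KBVIN cells (Homo sapiens) for antiproliferative activity, read by sulforhodamine B assay, with a stated time of 3 days (a higher number here means that more compound is needed for the effect, a lower number that less compound is needed), on the shared core:

compound 1 `CCC1=C(O)c2c(oc(-c3cccc(C)c3)cc2=O)C(CC)(CC)C1=O` gives 3.69 uM
compound 2 `CCC1=C(O)c2c(oc(-c3cccc(C(F)(F)F)c3)cc2=O)C(CC)(CC)C1=O` gives 5.42 uM
compound 3 `CCC1=C(O)c2c(oc(-c3cccc(OC)c3)cc2=O)C(CC)(CC)C1=O` gives 1.22 uM

Compound 3 has the lowest number of the three, and both gaps to it lie beyond the scatter. The two steps, a 3.0-fold lower number from compound 1 to compound 3 (0.48 log units; beyond the scatter) and a 4.4-fold lower number from compound 2 to compound 3 (0.65 log units; beyond the scatter), are each modest.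

Next comes compound 4 `CCC1=C(O)c2c(oc(-c3cccc(F)c3)cc2=O)C(CC)(CC)C1=O` where the change reads fluoro in place of methoxy on an aromatic carbon and turns 3-methoxyphenyl into 3-fluorophenyl, meta to a large group. Within the data shown here, no measured compound carries fluoro, so no measured step covers this change directly. The nearest evidence is the pair of steps above, read in reverse, since each shows what methoxy does when it replaces another group at this place. The step of a 1.5-fold higher number from compound 1 to compound 2 (0.17 log units; within the scatter) stays within the scatter, so methyl and trifluoromethyl are not separated here. If fluoro behaves like those two groups, the methoxy gain is lost and the number rises by a modest amount, though the data cannot confirm this. Expected, towards a higher number, is a 2.5-fold higher number from compound 3 to compound 4 (0.39 log units; beyond the scatter) in this assay as an estimate. For compound 4 the estimated value is 3 uM with an expected range from 1.3 uM to 6.5 uM as its ends.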

Compound 4, concentration for half-maximal effect: 3.09 uM
The estimate for compound 4 lay 1.0-fold (0.01 log units) below the measured number; the measured number falls inside the stated range.
By their numbers in this assay, from the lowest: compound 3; then compounds 4, 1 and 2 (each within the scatter of the next).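

In this assay the step of a 2.5-fold higher number from compound 3 to compound 4 (0.40 log units; beyond the scatter) shows that fluoro does not keep the low number seen with methoxy at this place on the aromatic ring, so the change from 3-methoxyphenyl to 3-fluorophenyl gives up the advantage of compound 3. Fluoro also falls in with the other two non-methoxy groups, since a 1.2-fold lower number from compound 1 to compound 4 (0.08 log units; within the scatter) and a 1.8-fold lower number from compound 2 to compound 4 (0.24 log units; within the scatter) both stay within the scatter; across the four groups, methyl, trifluoromethyl and fluoro are not separated, and methoxy alone stands apart, with compound 3 beyond the scatter from each of the other compounds. No measurement at hand bears on why methoxy differs from the other three groups here.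

Open, going by these compounds, is whether this advantage belongs to methoxy alone or extends to related groups at the same place, such as ethoxy, hydroxy or dimethylamino. Also open is whether methoxy gives the same result on another carbon of this ring, as every compound shown carries its group at this one place.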